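The source may hold more compounds than are shown below. What is called first, only, known or untested is meant among the compounds shown, and "the series" means these compounds.

Working notes on the series. Compound 1 `CC1CCC(=NNc2ccccc2)c2ncc(C(=O)O)c(=O)n21` gives 1.2 umol/kg in a functional assay on the whole organism with Rattus norvegicus as the target; on this read-out lower numbers stand for an effect already at smaller amounts and higher numbers for an effect only at larger amounts of compound. Compound 2 `CC1CCC(=NNc2ccccc2C(=O)O)c2ncc(C(=O)O)c(=O)n21` sits at a limit of this assay, > 100 umol/kg. Compound 3 `CC1CCC(=NNc2ccccc2)c2ncc(C(=O)NO)c(=O)n21` also sits at a limit, > 100 umol/kg, so only a bound is known for it. Compound 4 `CC1CCC(=NNc2ccccc2C(=O)O)c2ncc(C(=O)NO)c(=O)n21` differs from compound 3 by carboxy in place of hydrogen on an aromatic carbon. The same change was measured once: an at least 83-fold higher number from compound 1 to compound 2 (1.92 log units; beyond the scatter), a large loss. The other step, an at least 83-fold higher number from compound 1 to compound 3 (1.92 log units; beyond the scatter), already places compound 3 at the limit of > 100 umol/kg in this assay, at which 2 of the 3 values shown sit. Putting both changes together, no recovery is expected; compound 4 is estimated to remain at or beyond the limit, a step that the limit leaves unreadable from compound 3 to compound 4 from compound 3. The estimate for compound 4 in this assay is 300 umol/kg, within 100 umol/kg to 1000 umol/kg.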

Compound 4, dose for 50% inhibition: > 100 umol/kg
Compound 4: no number, only a limit (the forecaster's own chance of this, stated with the estimate: 90%); the middle value does not contradict the limit.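

Compound 4 gives only a limit, so the steps to it from compound 2 and compound 3 cannot be read: the limit of > 100 umol/kg in this assay, at which 3 of the 4 values shown sit. The compounds shown leave open how compound 2, compound 3 and compound 4 actually rank against one another.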